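This account rests on a few compounds, and the source may have more. Where it says the series, first, only, none or still open, it means among the compounds named here.

Measured compounds:
- compound 1, `COc1ccc2c(c1)OC(COc1ccc(CCC(=O)O)c(F)c1)CO2`, 80% in a functional assay on HEK293 cells for agonist activity at Free fatty acid receptor 1 (Homo sapiens), read by fluorescence and calcium flux, with a stated time of 10 min; on this read-out higher numbers stand for larger maximal responses and lower numbers for smaller maximal responses
- compound 2, `O=C(O)CCc1ccc(NCC2COc3ccc(Cl)cc3O2)cc1F`, 69% in this assay
- compound 3, `O=C(O)CC(c1ccc(OCC2COc3ccc(Cl)cc3O2)cc1)c1cnco1`, 63% in this assay

Compound 3 has the lowest of the three numbers. Its gap to compound 2 lies within the usual scatter of repeated measurements, so the two cannot be ranked against each other, while the gap to compound 1 lies beyond that scatter.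

Compound 4, `Cn1cncc1C(CC(=O)O)c1ccc(OCC2COc3ccc(Cl)cc3O2)cc1`, has not yet been measured. It differs from compound 3 in one place: 1-methyl-1H-imidazol-5-yl in place of 1,3-oxazol-5-yl on a saturated chain carbon bound to an aromatic carbon and a saturated chain carbon. Going by the values given here, nothing among the measured compounds shows what such an exchange does here, so there is no measured step to lean on. A small change, or none beyond the scatter, is expected, since the entering group resembles the leaving group in size and in the count of hydrogen-bond acceptors.

Compound 4 is expected to give 65%, with a range from 45% to 85%. This estimate means an expected step of a number 2 percentage points higher from compound 3 to compound 4 (within the scatter), one that stays within the scatter.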

Compound 4, largest response reached (Emax), in percent of the reference or control that the assay uses: 62%
For compound 4 the middle estimate is 3 percentage points above the measured one, within the range that was stated.
By their numbers in this assay, from the lowest: compounds 4, 3 and 2 (each within the scatter of the next); then compound 1.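

In this assay, putting 1-methyl-1H-imidazol-5-yl in place of 1,3-oxazol-5-yl on a saturated chain carbon bound to an aromatic carbon and a saturated chain carbon gives a number 1 percentage points lower from compound 3 to compound 4 (within the scatter). The maximal response therefore does not tell these two groups apart, even though the entering group has 6 heavy atoms against 5 and two nitrogens where the leaving group has a nitrogen and an oxygen. No measurement available here explains this result.

On these data alone, it remains open whether a group of a different kind on this carbon, such as an amine or a plain methyl, would give a response beyond the scatter of these two. As far as these compounds go, it is also open whether the same exchange would give a similar step on another core, such as the core of compound 1.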